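This account rests on a few compounds, and the source may have more. Where it says the series, first, only, none or still open, it means among the compounds named here.

Two compounds measured in a functional assay on MM1 cells (Homo sapiens) for antiproliferative activity, read by MTT assay, with a stated time of 72 h (on this read-out higher numbers stand for weaker inhibition and lower numbers for stronger inhibition), so far:
- compound 1 (`COc1ccc([C@H](C)NC(=O)/C(C#N)=C/c2cccc(Br)n2)cc1`): 1200 nM
- compound 2 (`N#C/C(=C\c1cccc(Br)n1)C(=O)N[C@@H](CO)c1ccccc1`): 2800 nM

Compound 1 holds the lower of the two numbers, and its gap to compound 2 lies beyond the scatter. Compound 3 (`C[C@H](NC(=O)/C(C#N)=C/c1cccc(Br)n1)c1ccc(N)cc1`) differs from compound 1 in one place: amino in place of methoxy on an aromatic carbon, para to a large group. Among the measured compounds shown here, no measured pair shows this change, so the expectation rests on compound 1 at 1200 nM alone. In this assay a small move towards a higher number is expected, possibly none beyond the scatter. The expected step is a 1.3-fold higher number from compound 1 to compound 3 (0.10 log units; within the scatter). Compound 3 is estimated at 1500 nM, with a range of 500 nM to 4500 nM.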

Compound 3, half-maximal inhibitory concentration: > 10000 nM
Compound 3: only a limit was reported; the forecaster's own chance of this, stated with the estimate: 3%; middle value at least 6.6-fold (0.82 log units) from the limit.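

The aromatic carbon para to a large group proves sensitive: amino in place of methoxy gives an at least 8.3-fold higher number from compound 1 to compound 3 (0.92 log units; beyond the scatter) in this assay. Compound 1 and compound 2 differ in more than one place and could not show this. The reading for compound 3 is a limit, not a number: the limit of > 10000 nM in this assay, at which 1 of the 3 values shown sits.

The compounds shown leave open whether this step belongs to the incoming amino or to the departing methoxy. A hydrogen, a hydroxyl or a dimethylamino on this carbon would separate the two.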